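Hydrazide series: lengthening the chain on the hydrazine nitrogen

The compounds below may be only part of what the source reports. "The series", "measured", "known", "first", "only" and "open" are said of these compounds alone.

Working notes on a small set of diacylhydrazines tested in an assay on cells for agonist activity at ecdysone receptor (Bombyx mori), read by a luciferase reporter, with a stated time of 24 h; a lower number here means that less compound is needed, a higher number that more compound is needed for the effect. Compound 1 `COc1ccccc1C(=O)N(NC(=O)c1ccccc1)C(C)(C)C` gives 525 nM in this assay. Compound 2 `COc1ccc(C(=O)NN(C(=O)c2ccccc2Cl)C(C)(C)C)cc1` gives 51.3 nM in this assay. Compound 3 `CN(NC(=O)c1ccccc1)C(=O)c1ccccc1` carries a methyl where compounds 1 and 2 carry a branched four-carbon group. In this assay compound 3 returns only a limit of the assay, > 100000 nM, not a number. That limit is the limit of > 100000 nM in this assay, at which 1 of the 3 values shown sits, so compound 3 stands below the reach of the measurement and its distance from compounds 1 and 2 cannot be put into figures.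

Compound 4 `CCCCN(NC(=O)c1ccccc1)C(=O)c1ccccc1` is the next member to be measured. It differs from compound 3 by propyl in place of hydrogen on a saturated chain carbon bound to an amide-type nitrogen, that is, methyl becomes butyl. For the measured compounds named here, no step between measured compounds is available as a guide for this change. The expectation is that compound 4 will move into the measurable range, with a step of an at least 5.0-fold lower number from compound 3 to compound 4 (0.69 log units; beyond the scatter) from the limit of compound 3, but well short of compound 1 and compound 2. Compound 4 is therefore estimated at 20000 nM, within a range from 3000 nM to 100000 nM.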

Compound 4, half-maximal effective concentration: 7080 nM
Compound 4: middle estimate off by 2.8-fold (0.45 log units), on the high side; low and high end bracket the measured number.
By their numbers in this assay, from the lowest: compound 2; then compound 1; then compound 4. At a limit, above all of these: compound 3.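

In this assay, for the compounds shown here, the change from methyl to butyl gives an at least 14-fold lower number from compound 3 to compound 4 (1.14 log units; beyond the scatter), the first step that can be read at this position. The earlier compounds shown here offered no such step; this one shows that the chain on this amide-type nitrogen alone, with the rest of the core unchanged, decides whether a measured value appears at all. For compound 3, > 100000 nM is a limit of the assay and not a number, so the step gives only a minimum size: the limit of > 100000 nM in this assay, at which 1 of the 4 values shown sits.

Two chain lengths do not show how the value follows chain length, so a propyl, a hexyl or a butyl chain ending in an amine or a carboxylic acid could each shift the picture. Also open, from the compounds shown here alone, is how a branched four-carbon group would compare with butyl on the core of compound 4.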